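Replacing 3-methoxyphenyl with 1,3-thiazol-2-yl on an amide-type nitrogen

The compounds below may be only part of what the source reports. "The series", "measured", "known", "first", "only" and "open" are said of these compounds alone.

Values so far in a functional assay on HCT-116 cells (Homo sapiens) for inhibition, read by colorimetric assay, with a stated time of 3 days (on this read-out lower numbers stand for stronger inhibition and higher numbers for weaker inhibition), are these
- compound 1 `O=C(CCCCCCNC(=O)C(O)(O)C(F)(F)F)Nc1ccc(F)cc1F` gives 18500 nM
- compound 2 `COc1cccc(NC(=O)CCCCCCNC(=O)C(O)(O)C(F)(F)F)c1` gives 6110 nM

Among the compounds with values here, the one measured step (a 3.0-fold lower number from compound 1 to compound 2 (0.48 log units; beyond the scatter)) leaves compound 2 with the lower of the two numbers, beyond the scatter. Compound 3 `O=C(CCCCCCNC(=O)C(O)(O)C(F)(F)F)Nc1nccs1` is unmeasured. Its difference from compound 2 is 1,3-thiazol-2-yl in place of 3-methoxyphenyl on an amide-type nitrogen and in short it puts 1,3-thiazol-2-yl in place of 3-methoxyphenyl on an amide-type nitrogen. Within the data shown here, the measured step changed the group at the same place, so it is the only guide, and it was modest. Among the measured compounds shown here, no measured compound carries 1,3-thiazol-2-yl. For the measured compounds named here, a modest step is therefore expected, with the direction uncertain and upward slightly favoured, as compound 2 at 6110 nM is the lower of only two numbers. The expected change is (a 1.6-fold higher number from compound 2 to compound 3 (0.21 log units; within the scatter)). Compound 3 is estimated at 10000 nM (range 3500 nM to 30000 nM).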

Compound 3, half-maximal inhibitory concentration: 10800 nM
For compound 3 the middle estimate is 1.1-fold (0.03 log units) below the measured one, and the stated range covers the measured number.
By their numbers in this assay, from the lowest: compounds 2, 3 and 1 (each within the scatter of the next, the first and the last beyond it).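

In this assay the step of a 1.8-fold higher number from compound 2 to compound 3 (0.25 log units; within the scatter) and the step of a 1.7-fold lower number from compound 1 to compound 3 (0.23 log units; within the scatter) show that a five-membered aromatic ring with 2 hetero atoms on the amide-type nitrogen, 1,3-thiazol-2-yl, cannot be told apart from either six-membered aryl group. Compound 1 and compound 2 remain separated beyond the scatter, so compound 3 fills the gap between them rather than extending the span of values at this position. No evidence on the cause of these differences is available.

Still open, going by these compounds, is whether a group of another kind on this nitrogen, such as a simple alkyl amine or a carboxylic acid, would fall outside this span. On these data alone, the effect of a shorter or longer chain with 1,3-thiazol-2-yl in place also remains open.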